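Changing One Stereocentre: Compound 2 to Compound 4

The source may report more compounds than this note shows. Statements on the series, on what has been measured and on what is new or still open speak of the compounds shown alone.

Measured in an ADME assay on microsomes from liver (Rattus norvegicus) for metabolic stability; on this read-out higher numbers stand for a longer-lived compound and lower numbers for a shorter-lived compound
- Compound 1 `Cc1cc(C(/C=C2\OC(=O)NC2=O)C(C)C)c(=O)[nH]c1-c1ccc2cccc(F)c2c1` gives > 3 h (a limit)
- Compound 2 `CC(C)[C@@H](c1ccc(-c2ccc3cccc(F)c3c2)[nH]c1=O)[C@@H]1OC(=O)NC1=O` gives 1.27 h
- Compound 3 `CCC(CC)C(/C=C1\OC(=O)NC1=O)c1ccc(-c2ccc3cccc(F)c3c2)[nH]c1=O` gives > 3 h (a limit)

Among these three results, compound 2 stands alone with an actual number, 1.27 h. The other two results are not numbers but limits of the assay: the limit of > 3 h in this assay, at which 2 of the 3 values shown sit.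

Compound 4 `CC(C)[C@@H](c1ccc(-c2ccc3cccc(F)c3c2)[nH]c1=O)[C@H]1OC(=O)NC1=O` has not yet been measured in this assay. Its structure relates to that of compound 2 as follows: the two compounds have the same atoms and bonds and differ only in configuration as drawn: 1 of 2 stereo elements differ; a stereocentre at a saturated ring carbon is drawn S in compound 2 and R in compound 4. Among the measured compounds shown here, no measured pair of compounds isolates a change of this kind, so the data offer no direct guide to its size or direction. The step of a 1.1-fold higher number from compound 2 to compound 4 (0.04 log units; within the scatter) is therefore expected to stay within the usual scatter, with no direction favoured, and the estimate is anchored on compound 2 at 1.27 h. The range is kept wide, as a larger change cannot be ruled out. Compound 4 is expected to give a half-life of about 1.4 h, within an estimated range of 0.6 h to 3 h.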

Compound 4, half-life: 1.93 h
Compound 4: the middle estimate sits 1.4-fold (0.14 log units) below what was measured; the measured number falls inside the stated range.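

At this saturated ring carbon, the change from S to R gives in this assay a step of a 1.5-fold higher number from compound 2 to compound 4 (0.18 log units; within the scatter) and so leaves the half-life within the usual scatter. Among the compounds shown here, this is the first step in the set that can be read as coming from this stereocentre alone, with nothing else altered: the fact that compounds 2 and 4 differ only in the configuration as drawn. Both compounds give actual numbers, which makes the comparison possible, whereas the other compounds stay at a limit: the limit of > 3 h in this assay, at which 2 of the 4 values shown sit.

From the compounds shown here alone, whether the second stereocentre, drawn alike in compound 2 and compound 4, matters as little remains open. Going by these compounds, it is also open whether this stereocentre would matter as little with a different group on the shared core, such as a carboxylic acid or an amine.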